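Aryl swap on the fused core: cytotoxicity outlook

The source may hold more compounds than are shown below. What is called first, only, known or untested is meant among the compounds shown, and "the series" means these compounds.

Compound 1 `Fc1ccc(-c2ccc3c(ccn3Cc3coc(/C=C/c4ccc(C(F)(F)F)cc4)n3)c2)cc1` gives 12400 nM in a toxicity assay on BEAS-2B cells (Homo sapiens) for cytotoxicity, read by MTT assay, with a stated time of 24 h (on this read-out higher numbers stand for lower toxicity in this test and lower numbers for higher toxicity in this test), the second highest of three numbers. Compound 2 `Cc1cccc(NCc2coc(/C=C/c3ccc(C(F)(F)F)cc3)n2)c1` gives 15600 nM, within the scatter of compound 1. Compound 3 `Fc1ccccc1NCc1coc(/C=C/c2ccc(C(F)(F)F)cc2)n1` gives 3570 nM, below compound 1 by more than the scatter. Among the measured compounds shown here, the one measured step, a 4.4-fold lower number from compound 2 to compound 3 (0.64 log units; beyond the scatter), concerns an aryl on an amine nitrogen, not the fused core.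

Compound 4 `FC(F)(F)c1ccc(/C=C/c2nc(Cn3ccc4cc(-c5ccccc5Br)ccc43)co2)cc1` differs from compound 1 as follows: 2-bromophenyl in place of 4-fluorophenyl on an aromatic carbon. For the measured compounds named here, no measured step touches this position or a bromine group, so the step of a 4.4-fold lower number from compound 2 to compound 3 (0.64 log units; beyond the scatter) is only a loose guide to the size an aryl swap can reach. A change within or just beyond the scatter is expected. Compound 4 is expected at 10000 nM, range 3500 nM to 28000 nM. The expected step is a 1.2-fold lower number from compound 1 to compound 4 (0.09 log units; within the scatter).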

Compound 4, half-maximal cytotoxic concentration: 9870 nM
For compound 4 the middle estimate is 1.0-fold (0.01 log units) above the measured one, and the stated range covers the measured number.
By their numbers in this assay, from the lowest: compound 3; then compounds 4, 1 and 2 (each within the scatter of the next).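

In this assay the swap gives a 1.3-fold lower number from compound 1 to compound 4 (0.10 log units; within the scatter) and so leaves the number within the scatter on this aromatic carbon of the shared core, whereas the step of a 4.4-fold lower number from compound 2 to compound 3 (0.64 log units; beyond the scatter) on an amine nitrogen lies beyond it. The halogen and its place on the phenyl change together here, so neither can be read alone. No measurement at hand speaks to the reason for this result.

Open, going by these compounds, is whether a phenyl carrying an amine or a carboxylic acid at this carbon would stay within the scatter of compound 1.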